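Amide cap variation and solubility: compound 3 to compound 4

A few compounds are considered here, and "the series" means these few. Any claim that something is new, unique, unknown or untested is made for them only; others in the source may bear on it.

Compound 3 `CCCCC(=O)N1CCN(c2nc(=O)c3cc(C(F)(F)F)cc([N+](=O)[O-])c3s2)CC1` gives 42.5 ug/mL in a physicochemical assay for solubility, read by HPLC; a higher number here means a more soluble compound, a lower number a less soluble compound. Of the three measured compounds it stands second highest. Its nearest neighbour is compound 2 `CCC(C)C(=O)N1CCN(c2nc(=O)c3cc(C(F)(F)F)cc([N+](=O)[O-])c3s2)CC1`, which gives 104 ug/mL in this assay; the two are separated by a 2.4-fold lower number from compound 2 to compound 3 (0.39 log units; beyond the scatter). Its furthest neighbour is compound 1 `Cc1ccc(C(=O)N2CCN(c3nc(=O)c4cc(C(F)(F)F)cc([N+](=O)[O-])c4s3)CC2)cc1`, which gives 6.7 ug/mL in this assay; here the separation is a 6.3-fold higher number from compound 1 to compound 3 (0.80 log units; beyond the scatter), and the same direction appears more strongly in a 16-fold higher number from compound 1 to compound 2 (1.19 log units; beyond the scatter).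

Compound 4 `O=C(C1CCCCC1)N1CCN(c2nc(=O)c3cc(C(F)(F)F)cc([N+](=O)[O-])c3s2)CC1` differs from compound 3 in one place: cyclohexyl in place of butyl on a carbonyl carbon. For the measured compounds named here, no measured step in this set introduces a carbocycle, so the closest guides are the two steps at the same carbonyl carbon. The move from a branched four-carbon chain to a straight one gave a 2.4-fold lower number from compound 2 to compound 3 (0.39 log units; beyond the scatter), a modest step; the move from the aromatic ring of compound 1 to the straight chain gave a 6.3-fold higher number from compound 1 to compound 3 (0.80 log units; beyond the scatter), a larger one. Compound 4 shares with compound 1 the presence of a ring, though a non-aromatic one, and is heavier than compound 3 by the counted two carbons. A modest downward step is therefore expected in this assay, a 2.1-fold lower number from compound 3 to compound 4 (0.33 log units; beyond the scatter). Compound 4 is estimated at 20 ug/mL in this assay, within a range from 8 ug/mL to 50 ug/mL.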

Compound 4, solubility: 3.24 ug/mL
For compound 4 the middle estimate is 6.2-fold (0.79 log units) above the measured one; the measured number lies below the stated range.
By their numbers in this assay, from the lowest: compound 4; then compound 1; then compound 3; then compound 2.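

For the compounds shown here, at the carbonyl carbon, cyclohexyl in place of butyl in this assay gives a 13-fold lower number from compound 3 to compound 4 (1.12 log units; beyond the scatter) and is the first change from an open chain to a carbocycle. The comparison with the branched chain is wider still, at a 32-fold lower number from compound 2 to compound 4 (1.51 log units; beyond the scatter) for this change, and the non-aromatic ring also ends up under the aromatic one, with a 2.1-fold lower number from compound 1 to compound 4 (0.32 log units; beyond the scatter) as the step between the two rings. Across the four compounds, the two ring-bearing caps thus hold the two lowest numbers and the two open chains the two highest, with no compound going against this, and no measurement on hand accounts for the size of these steps.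

Cyclohexyl differs from butyl both in having a ring and in its carbon count, so these compounds do not separate the two, and a hexyl chain or a cyclobutyl ring on the same carbonyl carbon would bear directly on that question. Also open, from the compounds shown here alone, is how a ring carrying a heteroatom would read in this assay at this place, such as a tetrahydropyranyl ring or a piperidine with its ring amine.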